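Removing the Aryl Ring from the Sulfonyl Group

The compounds below may be only part of what the source reports. "The series", "measured", "known", "first", "only" and "open" are said of these compounds alone.

Compound 2 `CCN(CC)c1ccc2cc(C(=O)c3ccc(N4CCN(S(=O)(=O)c5ccc(C)cc5)CC4)cc3)oc2c1` is the starting point here. In a functional assay on A549 cells (Homo sapiens) for cytotoxicity, read by MTT assay, with a stated time of 48 h (on this read-out higher numbers stand for weaker inhibition and lower numbers for stronger inhibition), compound 2 gives only a limit, > 40000 nM, not a number. This is the limit described by the limit of > 40000 nM in this assay, at which 1 of the 2 values shown sits. For the measured compounds named here, its close relative compound 1 `CCN(CC)c1ccc2cc(C(=O)c3ccc(N4CCN(S(=O)(=O)c5ccc(C(F)(F)F)cc5)CC4)cc3)oc2c1` gives 11100 nM in this assay, so the single measured step, an at least 3.6-fold higher number from compound 1 to compound 2 (0.55 log units; beyond the scatter), shows that exchanging one substituent on the aryl ring of the sulfonyl group already moves the read-out beyond the scatter.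

Compound 3 `CCN(CC)c1ccc2cc(C(=O)c3ccc(N4CCN(S(C)(=O)=O)CC4)cc3)oc2c1` goes a stage further: methyl in place of 4-methylphenyl on a sulfonyl sulfur. Going by the values given here, no measured step covers the loss of the whole aryl ring, and compound 2 already sits at the limit, so no further loss can be seen in this assay. Compound 3 is therefore expected to stay near that limit, a step that the limit leaves unreadable from compound 2 to compound 3, with an estimated 50000 nM lying between 20000 nM and 120000 nM.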

Compound 3, half-maximal inhibitory concentration: > 40000 nM
Compound 3 ended at the assay's limit; the forecaster's own chance of this, stated with the estimate: 70%; the middle value lies beyond the limit too.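

In this assay compound 3 gives a limit and not a number, so the position on the sulfonyl sulfur now has a methyl reading as well as two aryl readings. The step of an at least 3.6-fold higher number from compound 1 to compound 3 (0.55 log units; beyond the scatter) shows that methyl in place of 4-(trifluoromethyl)phenyl on a sulfonyl sulfur moves the read-out beyond the scatter, by the same minimum amount as the earlier exchange of substituents on the ring. The step between the two limits cannot be read, so nothing can be said about whether removing the 4-methylphenyl ring changes anything: the limit of > 40000 nM in this assay, at which 2 of the 3 values shown sit.

For the compounds shown here, of the three sulfonyl groups, only the one in compound 1 gives a number, so what that number depends on stays open. A nitrile or a chlorine on the aryl ring, or a longer chain such as propyl on the sulfur, could help to settle this.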